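The compounds below may be only part of what the source reports. "The series", "measured", "known", "first", "only" and "open" are said of these compounds alone.

Three compounds share one core and differ only in the group attached to the double-bonded nitrogen. Compound 1 `CC(C)(C)/N=C(\NC#N)Nc1cncc(Br)c1` carries a tert-butyl group there and a brominated ring; in a functional assay on the whole organism (blood, strain Wistar-Okamoto) with Rattus norvegicus as the target, with a stated time of 5 days (on this read-out lower numbers stand for an effect already at smaller amounts and higher numbers for an effect only at larger amounts of compound), compound 1 gives 0.5 mg/kg. Compound 2 `CCC(CC)/N=C(\NC#N)Nc1ccncc1` carries pentan-3-yl, and in this assay compound 2 gives 2.5 mg/kg. Compound 3 `CC(C)CC(C)/N=C(\NC#N)Nc1ccncc1` carries 1,3-dimethylbutyl, and in this assay compound 3 gives 35 mg/kg, the highest number of the three, meaning the weakest effect. Within the data shown here, the one step that can be followed directly is a 14-fold higher number from compound 2 to compound 3 (1.15 log units; beyond the scatter), so swapping one six-carbon group for another on this nitrogen moved the read-out strongly.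

Compound 4 `CCC(/N=C(\NC#N)Nc1ccncc1)C(C)C` is built from the same atoms as compound 3, joined differently: 1-isopropylpropyl in place of 1,3-dimethylbutyl on a double-bonded nitrogen. Among the measured compounds shown here, the entering group is, like pentan-3-yl in compound 2, branched at the carbon that sits on the nitrogen, whereas 1,3-dimethylbutyl is not; the only comparable step, a 14-fold higher number from compound 2 to compound 3 (1.15 log units; beyond the scatter), ran in the opposite direction. On that single step, a lower number than compound 3 is expected for compound 4, but with a single precedent the size is uncertain. The expected step is a 7.0-fold lower number from compound 3 to compound 4 (0.85 log units; beyond the scatter). For compound 4 the estimated value in this assay is 5 mg/kg, with a range from 1.5 mg/kg to 20 mg/kg.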

Compound 4, minimum effective dose: 5 mg/kg
Estimate against measurement, compound 4: no gap at the digits printed, within the range that was stated.
By their numbers in this assay, from the lowest: compound 1; then compounds 2 and 4 (each within the scatter of the next); then compound 3.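

In this assay the six carbons of the group on the double-bonded nitrogen were only rearranged, from 1,3-dimethylbutyl to 1-isopropylpropyl, yet the change gives a 7.0-fold lower number from compound 3 to compound 4 (0.85 log units; beyond the scatter) and so shows that the arrangement of these atoms matters at this position, not just their number. The comparison with pentan-3-yl gives a 2.0-fold higher number from compound 2 to compound 4 (0.30 log units; within the scatter) for a methyl in place of hydrogen on a saturated chain carbon bound to two saturated chain carbons, so this added methyl leaves compounds 2 and 4 indistinguishable, and among these three compounds only compound 3 stands apart. No supporting data are available that would explain why one arrangement differs from the other.

Going by these compounds, compound 1 differs from the others in both its tert-butyl group and its bromine, so its steps to them cannot be read and the contribution of each change stays unknown. On these data alone, it also remains open how a ring such as cyclohexyl, a longer chain such as n-heptyl, or a chain carrying a hydroxyl group would behave at this position.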